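The compounds below may be only part of what the source reports. "The series", "measured", "known", "first", "only" and "open" are said of these compounds alone.

Three compounds have been measured:

Compound 1, `Cc1ccc(OCc2ccccc2)c(C(C)NC(=O)NS(=O)(=O)c2ccc(Cl)cc2)c1`, gives 65300 nM in a functional assay on thoracic aorta (Rattus norvegicus, strain Wistar), with a stated time of 15 min; on this read-out higher numbers stand for an effect only at larger amounts of compound and lower numbers for an effect already at smaller amounts.
Compound 2, `CC(NC(=O)NS(=O)(=O)c1ccc(Cl)cc1)c1ccccc1OCc1ccccc1`, gives 157000 nM in this assay.
Compound 3, `COc1ccc(OC)c(CNC(=O)N(C)S(=O)(=O)c2ccccc2)c1`, gives 21300 nM in this assay.

Compound 1 and compound 2 differ in one place, (methyl in place of hydrogen on an aromatic carbon), and this change made a step of a 2.4-fold lower number from compound 2 to compound 1 (0.38 log units; beyond the scatter). Compound 3 carries a different core; the difference between the core of compound 3 and that of compound 2 is not broken down here. Compound 3 gives the lowest of the three numbers.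

Compound 4, `COc1ccc(OC)c(CNC(=O)N(C)S(=O)(=O)c2ccc(C)cc2)c1`, is not yet measured. It differs from compound 3 by methyl in place of hydrogen on an aromatic carbon. The place is not identical to that of the earlier change, which sat meta to a large group and para to a benzyloxy group, whereas here the methyl enters para to a large group, so this is the same kind of change rather than the same change. From compound 3 to compound 4 a step of a 1.5-fold lower number from compound 3 to compound 4 (0.18 log units; within the scatter) is expected in this assay, a somewhat smaller step than the earlier one because a 2.4-fold lower number from compound 2 to compound 1 (0.38 log units; beyond the scatter) was measured on a different core. The estimate for compound 4 is 14000 nM, with a range from 5000 nM to 40000 nM.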

Compound 4, half-maximal effective concentration: 20900 nM
For compound 4 the middle estimate is 1.5-fold (0.17 log units) below the measured one; low and high end bracket the measured number.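

In this assay, methyl in place of hydrogen on an aromatic carbon, here phenyl to 4-methylphenyl, gave a 1.0-fold lower number from compound 3 to compound 4 (0.01 log units; within the scatter), so on this core the change had no effect that can be told from the scatter. Set beside the step on the other core, the new step cannot be told apart from it: the same change on two cores in this assay, a 2.4-fold lower number (0.38 log units; beyond the scatter) from compound 2 to compound 1 and a 1.0-fold lower number (0.01 log units; within the scatter) from compound 3 to compound 4, 2.4-fold (0.37 log units) apart, within the scatter of two such steps. Among these compounds, this gives no ground for saying that the change behaves differently on the two cores, but it does not show that its effect carries over reliably, since only two pairs are compared, the methyl does not sit in the same place in both, and only one of the two steps lies beyond the scatter.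

The compounds shown leave open how an ethyl, trifluoromethyl or amine group would read at the place para to a large group on the core of compound 3. They also leave open whether a third core would give a step closer to the larger or the smaller of these two.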